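Trimethoxyphenyl benzoxazoles: swapping the methoxyphenyl arm for fluorophenyl

A few compounds are considered here, and "the series" means these few. Any claim that something is new, unique, unknown or untested is made for them only; others in the source may bear on it.

Measured compounds:
Compound 1, `COc1cc(-c2cccc3nc(-c4ccccc4)oc23)cc(OC)c1OC`, 20300 nM
Compound 2, `COc1ccc(-c2nc3cccc(-c4cc(OC)c(OC)c(OC)c4)c3o2)cc1`, 2200 nM
Compound 3, `COc1ccc(-c2nc3cccc(-c4cc(OC)c(OC)c(OC)c4)c3o2)cc1OC`, 2800 nM

In a functional assay on A549 cells (Homo sapiens) for antiproliferative activity, read by MTT assay, with a stated time of 48 h (on this read-out lower numbers stand for stronger inhibition and higher numbers for weaker inhibition), compound 3 stands second highest of the three numbers. Its nearest neighbour is compound 2, within the scatter of it, and its furthest is compound 1, which sits well above it: a 7.3-fold lower number from compound 1 to compound 3 (0.86 log units; beyond the scatter).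

Compound 4, `COc1cc(-c2cccc3nc(-c4cccc(F)c4)oc23)cc(OC)c1OC`, has not been measured. It differs from compound 3 in one place: 3-fluorophenyl in place of 3,4-dimethoxyphenyl on an aromatic carbon.

Among the measured compounds shown here, two measured steps bear on this change. Both added methoxy to the phenyl arm of compound 1 and both lowered the number: a 9.2-fold lower number from compound 1 to compound 2 (0.97 log units; beyond the scatter) and a 7.3-fold lower number from compound 1 to compound 3 (0.86 log units; beyond the scatter). For the measured compounds named here, compound 4 goes the other way, removing both methoxy groups and leaving a 3-fluorophenyl for which no step exists, so an increase in this assay is expected, though of uncertain size. The expected step is a 4.3-fold higher number from compound 3 to compound 4 (0.63 log units; beyond the scatter). Compound 4 is therefore estimated at 12000 nM, with a range from 4000 nM to 36000 nM.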

Compound 4, half-maximal inhibitory concentration: 2600 nM
The estimate for compound 4 lay 4.6-fold (0.66 log units) above the measured number, outside the stated range (below it).
By their numbers in this assay, from the lowest: compounds 2, 4 and 3 (each within the scatter of the next); then compound 1.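

In this assay, the 3-fluorophenyl arm at this position reads level with both methoxy-bearing arms, with a 1.1-fold lower number from compound 3 to compound 4 (0.03 log units; within the scatter) and a 1.2-fold higher number from compound 2 to compound 4 (0.07 log units; within the scatter), so methoxy is not required on this arm for a number in this range. Fluoro in place of hydrogen on the phenyl arm of compound 1 gives a 7.8-fold lower number from compound 1 to compound 4 (0.89 log units; beyond the scatter), a step of about the same size as those seen with methoxy, and all three substituted arms therefore sit apart from the unsubstituted phenyl arm. No measurement shown here accounts for why such different groups give matching numbers.

The compounds shown leave open whether any substituent on this arm would serve equally well, or whether the match holds only for methoxy and fluoro. An amine or a carboxylic acid on the same arm would test that, as would fluoro placed elsewhere on the ring.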